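The compounds below may be only part of what the source reports. "The series", "measured", "known", "first", "only" and "open" are said of these compounds alone.

Among the compounds with values here, in an ADME assay on L6 cells (Rattus norvegicus) for cytotoxicity, read by resazurin assay (on this read-out higher numbers stand for weaker inhibition and lower numbers for stronger inhibition), compound 1 `N=C(N)c1ccc2[nH]c(-c3ccc4nc(-c5ccccc5F)[nH]c4c3)nc2c1` gives 26.8 ug/mL, while compound 2 `N=C(N)c1ccc2[nH]c(-c3ccc4nc(-c5ccc(F)cc5)[nH]c4c3)nc2c1` gives 2.48 ug/mL, the lowest number so far. Compound 3 `COc1ccc(-c2nc3ccc(-c4nc5cc(C(=N)N)ccc5[nH]4)cc3[nH]2)cc1OC` reads > 90 ug/mL, which is a limit of the assay. Compound 4 `N=C(N)c1ccc2[nH]c(-c3ccc4nc(-c5ccc(OCc6ccccc6)cc5)[nH]c4c3)nc2c1` differs from compound 2 by one change: benzyloxy in place of fluoro on an aromatic carbon, with benzyloxy in place of fluoro on an aromatic carbon. The closest guide is an at least 36-fold higher number from compound 2 to compound 3 (1.55 log units; beyond the scatter), where 3,4-dimethoxyphenyl replaces 4-fluorophenyl, although that size rests on a limit. Changes at this same place also gave an 11-fold lower number from compound 1 to compound 2 (1.03 log units; beyond the scatter) and an at least 3.3-fold higher number from compound 1 to compound 3 (0.52 log units; beyond the scatter), so a clear move is expected, towards a higher number. The expected size is a 4.8-fold higher number from compound 2 to compound 4 (0.68 log units; beyond the scatter). For compound 4 the estimated value is 12 ug/mL, with an expected range from 3 ug/mL to 50 ug/mL.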

Compound 4, half-maximal inhibitory concentration: 17.4 ug/mL
Estimate against measurement, compound 4: 1.5-fold (0.16 log units) below; the measured number falls inside the stated range.
By their numbers in this assay, from the lowest: compound 2; then compounds 4 and 1 (each within the scatter of the next). At a limit, above all of these: compound 3.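

In this assay, benzyloxy in place of fluoro gives a 7.0-fold higher number from compound 2 to compound 4 (0.85 log units; beyond the scatter), so a much larger group carrying an extra aromatic ring still leaves a measurable number at this position. This step has an exact size, which the steps to compound 3 lack. Compound 3 is a limit and not a number: the limit of > 90 ug/mL in this assay, at which 1 of the 4 values shown sits.

The compounds shown leave open how an amine or a carboxylic acid at this place would read. They also leave open whether a single methoxy would read closer to compound 2 or to compound 4.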